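Aryl fluoro to methyl on the methylpiperidine analogue

The source may report more compounds than this note shows. Statements on the series, on what has been measured and on what is new or still open speak of the compounds shown alone.

Working notes on the series. Compound 1 `COc1cc2c(Oc3ccc(NC(=O)c4nnn(-c5ccc(C)cc5)c4C(F)(F)F)cc3F)ccnc2cc1OCCCN1CCCC1` gives 370 nM in a functional assay on A549 cells (Homo sapiens) for cytotoxicity, read by MTT assay, with a stated time of 72 h; a lower number here means a stronger inhibitor, a higher number a weaker inhibitor. Compound 2 `COc1cc2c(Oc3ccc(NC(=O)c4nnn(-c5ccc(F)cc5)c4C(F)(F)F)cc3F)ccnc2cc1OCCCN1CCCCC1` gives 110 nM in this assay, and compound 3 `COc1cc2c(Oc3ccc(NC(=O)c4nnn(-c5ccc(F)cc5)c4C(F)(F)F)cc3F)ccnc2cc1OCCCN1CCC(C)CC1` gives 120 nM. Compound 3 thus stands second highest of the three numbers, nearest compound 2 and furthest from compound 1. For the measured compounds named here, the one single-point step measured so far, a 1.1-fold higher number from compound 2 to compound 3 (0.04 log units; within the scatter), concerns the saturated ring only and is within the scatter.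

Compound 4 `COc1cc2c(Oc3ccc(NC(=O)c4nnn(-c5ccc(C)cc5)c4C(F)(F)F)cc3F)ccnc2cc1OCCCN1CCC(C)CC1` differs from compound 3 by methyl in place of fluoro on an aromatic carbon. Going by the values given here, no measured step isolates this change: compound 1 and compound 2 differ both at the aryl group and at the saturated ring, so the value of compound 1 at 370 nM and that of compound 2 at 110 nM cannot be attributed to the aryl substituent alone. The methyl-bearing compound 1 does carry the highest number shown, so a modest rise is expected for compound 4, namely a 1.7-fold higher number from compound 3 to compound 4 (0.22 log units; within the scatter) in this assay, with wide uncertainty. The estimate for compound 4 is 200 nM, between 80 nM and 500 nM.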

Compound 4, half-maximal inhibitory concentration: 400 nM
The estimate for compound 4 lay 2.0-fold (0.30 log units) below the measured number; the measured number falls inside the stated range.
By their numbers in this assay, from the lowest: compounds 2 and 3 (each within the scatter of the next); then compounds 1 and 4 (each within the scatter of the next).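

In this assay, for the compounds shown here, the change from 4-fluorophenyl to 4-methylphenyl now stands alone on an otherwise identical structure, giving a 3.3-fold higher number from compound 3 to compound 4 (0.52 log units; beyond the scatter), the first single-place step at this position and one beyond the scatter. Going by these compounds alone, with the 4-methylphenyl group held constant, the side-chain ring swap gives a 1.1-fold higher number from compound 1 to compound 4 (0.03 log units; within the scatter), so this pair does not separate, and the aryl change is the only measured single-place step here to exceed the scatter. No available data explain the size of the aryl step.

Going by these compounds, whether hydrogen, chloro, methoxy or a nitrile at this position would track with compound 3 or compound 4 remains open. Also open, on these data alone, is whether the fluoro-to-methyl step has a similar size with pyrrolidin-1-yl or piperidin-1-yl at the chain end.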